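The source may hold more compounds than are shown below. What is called first, only, known or untested is meant among the compounds shown, and "the series" means these compounds.

Going by the values given here, in an ADME assay (liver) for metabolic stability, with Liver microsome (Homo sapiens) as the target, using microsomes (on this read-out higher numbers stand for fast clearance and lower numbers for slow clearance), compound 1 `Cc1cnc(NC(=O)c2cc(Oc3ccc(S(C)(=O)=O)cc3)c3cc(C)oc3c2)cn1` gives 13 mL/min/kg as the only actual number so far. Compound 2 `Cc1cnc(NC(=O)c2cc(Oc3ncc(C(=O)N(C)C)cn3)c3cc(C)oc3c2)cn1` is reported at < 8 mL/min/kg and that is a limit of the assay, not a number. Compound 3 `CNC(=O)c1cnc(Oc2cc(C(=O)Nc3cnc(C)cn3)cc3oc(C)cc23)cn1` carries 5-(methylcarbamoyl)pyrazin-2-yl in place of 4-(methylsulfonyl)phenyl on an oxygen on an aromatic ring. Among the compounds with values here, no measured step tests this change, so in this assay the expected move is slightly downward and no larger than the scatter, with an estimated 1.4-fold lower number from compound 1 to compound 3 (0.14 log units; within the scatter) as its size. Compound 3 is expected at 9.5 mL/min/kg with an estimated range from 5 mL/min/kg to 18 mL/min/kg on this read-out.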

Compound 3, clearance: 10.1 mL/min/kg
Compound 3: the middle estimate sits 1.1-fold (0.03 log units) below what was measured; measured number inside the range.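

In this assay, going by these compounds alone, the first measured step at this position, on an oxygen on an aromatic ring, replaces 4-(methylsulfonyl)phenyl with 5-(methylcarbamoyl)pyrazin-2-yl and gives a 1.3-fold lower number from compound 1 to compound 3 (0.11 log units; within the scatter). The two groups therefore cannot be told apart on clearance in this pair. Compound 2 remains a limit and not a number, and steps to it cannot be read: the limit of < 8 mL/min/kg in this assay, at which 1 of the 3 values shown sits.

On these data alone, the ring and the methylcarbamoyl group enter together, so what each contributes stays open. Also open, as far as these compounds go, is whether an amine or a carboxylic acid on that ring would shift clearance beyond the scatter.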